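The compounds below may be only part of what the source reports. "The series", "measured", "known", "first", "only" and "open" are said of these compounds alone.

Measured in a functional assay on A549 cells (Homo sapiens) for cytotoxicity; on this read-out lower numbers stand for stronger inhibition and higher numbers for weaker inhibition:

- Compound 1 `CC(C)=CCCC1=CCC2=C(C1)C(=O)C=CC2=O`: 2100 nM
- Compound 2 `CC(C)=CCCc1ccc2c(c1)C(=O)C=CC2=O`: 1000 nM

Of these two compounds, compound 2 has the lower number and so shows the stronger inhibition. Compound 1 stands at 2100 nM, and this gap lies beyond the usual scatter of repeated measurements.

The next compound to be tested in this assay is compound 3 `CC(C)=CCCc1ccc2c(c1)C(=O)C(C)=CC2=O`. Compared with compound 2, it carries a methyl in place of hydrogen on a double-bonded ring carbon. This is a small edit, and the rest of the structure stays the same.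

Among the compounds with values here, no measured pair of compounds shows what this kind of change does, so any forecast is uncertain. The best starting point is compound 2 at 1000 nM. A small shift towards weaker inhibition is expected, but one that stays within the scatter. The estimated change is a 1.2-fold higher number from compound 2 to compound 3 (0.08 log units; within the scatter), and no step beyond the scatter is expected. For compound 3 the expected value is 1200 nM, with an estimated range from 450 nM to 3200 nM.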

Compound 3, half-maximal inhibitory concentration: 3900 nM
For compound 3 the middle estimate is 3.3-fold (0.51 log units) below the measured one, and the stated range ends below it.
By their numbers in this assay, from the lowest: compound 2; then compounds 1 and 3 (each within the scatter of the next).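

Measured in this assay, placing a methyl in place of hydrogen on a double-bonded ring carbon gives a 3.9-fold higher number from compound 2 to compound 3 (0.59 log units; beyond the scatter). Within the data shown here, this is the first look at this position, and it shows that the ring carbon is not indifferent to substitution: a group of a single heavy atom is enough to weaken inhibition beyond the scatter, while the rest of the structure stays the same. The data shown offer no measurement that could explain this loss of inhibition, so its reason remains unknown.

A single pair cannot tell whether the loss belongs to methyl in particular or would appear with any group on this carbon; an ethyl, a longer chain, a fluorine or an amine at the same place would help to separate those possibilities. From the compounds shown here alone, it also remains open whether the same methyl would have a similar effect on the core of compound 1, where the ring bearing the side chain is not the same as in compound 2.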